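The source may report more compounds than this note shows. Statements on the series, on what has been measured and on what is new or still open speak of the compounds shown alone.

Compound 1, `CC(C)(C)OC[C@@H](O)C(=O)N1[C@H](C(=O)NCc2cc(Cl)ccc2-n2cnnn2)C[C@@H]2C[C@@H]21`: 500 nM
Compound 2, `O=C(NCc1cc(Cl)ccc1-n1cnnn1)[C@@H]1CC=NN1C(=O)[C@H](O)c1ccccc1F`: 1100 nM
Compound 3, `O=C(NCc1cc(Cl)ccc1-n1cnnn1)[C@@H]1CCON1C(=O)[C@H](O)c1ccccc1`: 1500 nM

In a functional assay on a cell-free system (plasma, Homo sapiens), with a stated time of 3 min (a higher number here means a weaker inhibitor, a lower number a stronger inhibitor), compound 2 holds the second highest of the three numbers; compound 3 lies within the scatter of it, while compound 1 is further off, beyond the scatter. Compound 4, `CC(C)(C)OC[C@@H](O)C(=O)N1N=CC[C@H]1C(=O)NCc1cc(Cl)ccc1-n1cnnn1`, differs from compound 2 in one place: (tert-butoxy)methyl in place of 2-fluorophenyl on a saturated chain carbon bound to a carbonyl carbon and an oxygen on a saturated carbon. Going by the values given here, no measured pair isolates this change; compound 1 carries the (tert-butoxy)methyl group on a different core and gives 500 nM. A small step downward is expected from compound 2 to compound 4, a 1.6-fold lower number from compound 2 to compound 4 (0.20 log units; within the scatter), possibly not beyond the scatter. Compound 4 is estimated at 700 nM, with a range of 300 nM to 1600 nM.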

Compound 4, half-maximal inhibitory concentration: 750 nM
For compound 4 the middle estimate is 1.1-fold (0.03 log units) below the measured one; measured number inside the range.
By their numbers in this assay, from the lowest: compounds 1, 4, 2 and 3 (each within the scatter of the next, the first and the last beyond it).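

In this assay, (tert-butoxy)methyl in place of 2-fluorophenyl gives a 1.5-fold lower number from compound 2 to compound 4 (0.17 log units; within the scatter). On this shared core, then, this saturated chain carbon carries either the open chain without a ring or the six-membered aromatic ring with no separable difference in the number. No supporting measurement bears on why the two groups read alike. Open, as far as these compounds go, is whether a single pair generalises to other groups here, such as an amine, a carboxylic acid or a longer chain. Also open, from the compounds shown here alone, is whether unsubstituted phenyl reads the same on this core.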